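Removing the Benzoyl Group from Compound 3

This account rests on a few compounds, and the source may have more. Where it says the series, first, only, none or still open, it means among the compounds named here.

Compound 1 `Cc1nnc(SCC(=O)c2ccccc2)n1N1C(=O)c2ccccc2C1=O`, compound 2 `CSc1nnc(C)n1N1C(=O)c2ccccc2C1=O` and compound 3 `CCCc1nnc(SCC(=O)c2ccccc2)n1N1C(=O)c2ccccc2C1=O` were all tested in a functional assay on HepG2 cells (Homo sapiens) for cytotoxicity, read by MTT assay, with a stated time of 48 h; a higher number here means a weaker inhibitor, a lower number a stronger inhibitor. In this assay compound 1 gives > 200000 nM, which is a limit of the assay and not a number. In this assay compound 2 gives > 200000 nM, likewise a limit. In this assay compound 3 gives > 200000 nM, again a limit rather than a measured value.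

The change from compound 1 to compound 2 is hydrogen in place of benzoyl on a saturated chain carbon bound to a sulfur, and the step it made is a step that the two limits leave unreadable from compound 1 to compound 2; its size cannot be read because of the limit of > 200000 nM in this assay, at which 3 of the 3 values shown sit. Compound 3 differs from compound 1 by ethyl in place of hydrogen on a saturated chain carbon bound to an aromatic carbon, with a step that the two limits leave unreadable from compound 1 to compound 3, which is unreadable for the same reason.

Compound 4 `CCCc1nnc(SC)n1N1C(=O)c2ccccc2C1=O` has not yet been measured in this assay. It differs from compound 3 by hydrogen in place of benzoyl on a saturated chain carbon bound to a sulfur, the same change as that from compound 1 to compound 2, at the same place. That earlier step gives no size to carry over, and every measured compound in this series sits at the limit of > 200000 nM in this assay, at which 3 of the 3 values shown sit. The step from compound 3 to compound 4 is therefore expected to be a step that the limit leaves unreadable from compound 3 to compound 4. Compound 4 is expected to give 300000 nM in this assay, most probably reported once more only as a limit. The expected range for compound 4 runs from 150000 nM to 1000000 nM.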

Compound 4, half-maximal inhibitory concentration: > 200000 nM
Compound 4 was reported as a limit; the forecaster's own chance of this, stated with the estimate: 85%; the middle value does not contradict the limit.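

In this assay compound 4 gives > 200000 nM, which is a limit and not a number. No new step can be read between compound 4 and either compound 2 or compound 3, because all the values remain at one limit: the limit of > 200000 nM in this assay, at which 4 of the 4 values shown sit.

The compounds shown leave open whether hydrogen in place of benzoyl, or ethyl in place of hydrogen, has any effect in this assay.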